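The compounds below may be only part of what the source reports. "The series", "measured", "known", "first", "only" and "open" are said of these compounds alone.

Measured compounds:
- compound 1 `CC1=C(C(=O)OCC(C)C)C(c2cccs2)NC(=O)N1`: 25%
- compound 2 `CC1=C(C(=O)OC(C)(C)C)C(c2cccs2)NC(=S)N1`: 22%
- compound 3 `CC1=C(C(=O)OCC(C)C)C(c2cccs2)NC(=O)N1C`: 9%

The values come from an assay on membranes from CHO cells for displacement of a labelled ligand from adenosine receptor A1 (Homo sapiens), read by scintillation counting, with a stated time of 60 min, tested at 1 uM; a lower number here means less inhibition, a higher number more inhibition at the concentration tested (going by the name of the read-out). Among the three measured compounds, compound 1 gives the highest number, though compound 2 lies within the scatter of it, so nothing separates these two. Compound 3 sits furthest from compound 1: the step of a number 16 percentage points lower from compound 1 to compound 3 (beyond the scatter) is beyond the scatter, and it goes with a methyl in place of hydrogen on an amide-type nitrogen in a ring.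

The compound not yet measured is compound 4 `CC1=C(C(=O)OCC2CC2)C(c2cccs2)NC(=O)N1`. It differs from compound 1 in cyclopropyl in place of isopropyl on a saturated chain carbon bound to an oxygen next to a carbonyl group. Among the compounds with values here, none of the measured steps touches the ester side of the shared core; the only step beyond the scatter concerns the ring nitrogen and bears no direct relation to this change. Within the data shown here, the comparison of compound 1 with compound 2 shows only that a change at a different part of the core left the number within the scatter. Among the measured compounds shown here, with no step on the ester group to lean on, the expected step of a number 1 percentage points lower from compound 1 to compound 4 (within the scatter) is small and may not exceed the scatter. Compound 4 is therefore estimated to give 24% in this assay, with a range from 10% to 40%.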

Compound 4, a percentage reported as inhibition, at one concentration (the size of the read-out at that concentration, not a potency): 23%
The estimate for compound 4 lay 1 percentage points above the measured number; measured number inside the range.
By their numbers in this assay, from the lowest: compound 3; then compounds 2, 4 and 1 (each within the scatter of the next).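

Within the data shown here, compound 4 gives the first reading on the ester side of the shared core. In this assay, the step of a number 2 percentage points lower from compound 1 to compound 4 (within the scatter) shows that cyclopropyl in place of isopropyl, on a saturated chain carbon bound to an oxygen next to a carbonyl group, leaves the number within the scatter, so adding a three-membered ring of carbon only, with the heavy-atom count of the exchanged group unchanged, does not separate the two compounds at the concentration tested. This contrasts with the methyl on the amide-type nitrogen in the ring, where a number 16 percentage points lower from compound 1 to compound 3 (beyond the scatter) remains the only step beyond the scatter, and nothing shown here explains why the two ester groups read alike.

As far as these compounds go, whether a longer chain, a benzyl group or a terminal amine in the same place would move the number beyond the scatter remains open. Also open, from the compounds shown here alone, is whether compound 1 and compound 4 would still read alike as potencies, as the read-out here comes from one concentration only.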